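Shortening the hydroxycarbamoyl chain of compound 1

This account rests on a few compounds, and the source may have more. Where it says the series, first, only, none or still open, it means among the compounds named here.

Measured compounds:
- compound 1 `Nc1nc2cc(-c3nn(CCCCCCCCCC(=O)NO)c4ncnc(N)c34)ccc2o1` gives 41200 nM
- compound 2 `Nc1ncnc2c1c(-c1cnc3[nH]ccc3c1)nn2CCCCCCCCCC(=O)NO` gives 10100 nM

In a functional assay on Huh-7 cells (Homo sapiens) for inhibition, read by MTT assay, with a stated time of 72 h (on this read-out higher numbers stand for weaker inhibition and lower numbers for stronger inhibition), compound 1 holds the higher of the two numbers (41200 nM). Compound 3 `Nc1nc2cc(-c3nn(CCCCC(=O)NO)c4ncnc(N)c34)ccc2o1` keeps the core of compound 1 but has a much shorter chain (hydroxycarbamoyl in place of 5-(hydroxycarbamoyl)pentyl on a saturated chain carbon, four bonds along the chain from an aromatic nitrogen). Within the data shown here, the only measured step (a 4.1-fold lower number from compound 1 to compound 2 (0.61 log units; beyond the scatter)) changes the aromatic group, not the chain, so it offers a rough scale but no direction. No chain variation has been measured, so a modest move toward lower numbers in this assay is only a tentative expectation. The expected step is (a 2.1-fold lower number from compound 1 to compound 3 (0.31 log units; beyond the scatter)). For compound 3 the estimated value is 20000 nM, with an expected range from 4000 nM to 70000 nM.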

Compound 3, half-maximal inhibitory concentration: 9220 nM
Compound 3: middle estimate off by 2.2-fold (0.34 log units), on the high side; low and high end bracket the measured number.
By their numbers in this assay, from the lowest: compounds 3 and 2 (each within the scatter of the next); then compound 1.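

In this assay, cutting 5-(hydroxycarbamoyl)pentyl back to hydroxycarbamoyl at this saturated chain carbon gives a 4.5-fold lower number from compound 1 to compound 3 (0.65 log units; beyond the scatter). This shows that the chain itself moves the number on the core of compound 1, and that shortening it goes toward stronger inhibition. Nothing at hand explains this shift.

As far as these compounds go, two chain lengths on one core give no trend, so it remains open whether intermediate lengths would fall on the same line. Also open, from the compounds shown here alone, are whether a carboxylic acid or an amine could replace the hydroxycarbamoyl end, and whether the shorter chain acts alike with the aromatic group of compound 2.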